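Replacing 2-phenylethenyl with 3,4-dimethylphenyl on a shared core

A few compounds are considered here, and "the series" means these few. Any claim that something is new, unique, unknown or untested is made for them only; others in the source may bear on it.

Compound 1 `CCCCCCN1CCC(C(=O)Nc2cc(Cl)c(N)cc2OC)CC1` gives > 10 mg/kg in a functional assay on the whole organism for antagonist activity, with Mus musculus as the target (on this read-out lower numbers stand for an effect already at smaller amounts and higher numbers for an effect only at larger amounts of compound), which is a limit of the assay rather than a number.
Compound 2 `COc1cc(N)c(Cl)cc1NC(=O)C1CCN(C/C=C/c2ccccc2)CC1` gives > 10 mg/kg in this assay, likewise a limit.
Compound 3 `COc1cc(N)c(Cl)cc1NC(=O)C1CCN(CC2CCCC2)CC1` gives > 10 mg/kg in this assay, again a limit.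

Compound 2 thus stands at the limit of > 10 mg/kg in this assay, at which 3 of the 3 values shown sit, with nothing to set it apart from the other two. The three steps among the measured compounds, a step that the two limits leave unreadable from compound 1 to compound 2, a step that the two limits leave unreadable from compound 1 to compound 3 and a step that the two limits leave unreadable from compound 2 to compound 3, all run between limits, and none has a readable size. Compound 4 `COc1cc(N)c(Cl)cc1NC(=O)C1CCN(Cc2ccc(C)c(C)c2)CC1` differs from compound 2 by 3,4-dimethylphenyl in place of 2-phenylethenyl on a saturated chain carbon bound to an amine nitrogen in a ring. Cut one bond further out, the same difference reads 3-phenylprop-2-en-1-yl to 3,4-dimethylbenzyl. Within the data shown here, no measured step bears on this change with a readable size, and no direction beyond the scatter can be expected. Compound 4 is estimated at 15 mg/kg, within 5 mg/kg to 50 mg/kg. The expected step is a step that the limit leaves unreadable from compound 2 to compound 4. Most likely the assay again reports only a limit.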

Compound 4, dose for half-maximal effect: > 8 mg/kg
Compound 4: only a limit was reported; the forecaster's own chance of this, stated with the estimate: 75%; the middle value does not contradict the limit.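

Among these compounds, compound 1, compound 2, compound 3 and compound 4 all give only limits, so no step to compound 4 can be read. The compounds shown leave open whether their differing groups change the dose needed in this assay at all.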